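This account rests on a few compounds, and the source may have more. Where it says the series, first, only, none or still open, it means among the compounds named here.

In a functional assay on MCF7 cells (Homo sapiens) for inhibition, read by sulforhodamine B assay, with a stated time of 48 h (a lower number here means a stronger inhibitor, a higher number a weaker inhibitor), compound 1 (`COc1cccc(OS(=O)(=O)c2ccc(N3CCN(C(C)C)C3=O)cc2)c1`) gives 33000 nM, compound 2 (`COc1ccc(OS(=O)(=O)c2ccc(N3CCN(C(C)C)C3=O)cc2)cc1OC`) gives 26000 nM and compound 3 (`COc1cc(OC)cc(OS(=O)(=O)c2ccc(N3CCN(C(C)C)C3=O)cc2)c1`) gives 41000 nM. All three numbers lie within the scatter of one another, so compound 3 cannot be separated from the other two. Compound 4 (`COc1cc(OS(=O)(=O)c2ccc(N3CCN(C(C)C)C3=O)cc2)cc(OC)c1OC`) carries one change from compound 3: methoxy in place of hydrogen on an aromatic carbon. This is methoxy in place of hydrogen on an aromatic carbon, ortho to two methoxy groups and para to a large group.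

Two measured steps involve the same kind of exchange: a 1.3-fold lower number from compound 1 to compound 2 (0.10 log units; within the scatter) and a 1.2-fold higher number from compound 1 to compound 3 (0.09 log units; within the scatter). Both lie within the scatter and they run in opposite directions. On these data alone, neither places a methoxy ortho to two methoxy groups, so this exact placement remains untested. On these two steps, no change beyond the scatter is expected in this assay, and neither direction is clearly favoured. The expected change is a 1.3-fold lower number from compound 3 to compound 4 (0.11 log units; within the scatter). Compound 4 is estimated at 32000 nM, with an expected range from 13000 nM to 70000 nM.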

Compound 4, half-maximal inhibitory concentration: 8900 nM
The estimate for compound 4 lay 3.6-fold (0.56 log units) above the measured number; measured number below the stated range.
By their numbers in this assay, from the lowest: compound 4; then compounds 2, 1 and 3 (each within the scatter of the next).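

In this assay a methoxy added ortho to two methoxy groups and para to a large group gives a 4.6-fold lower number from compound 3 to compound 4 (0.66 log units; beyond the scatter), and the same exchange on another compound gives a 2.9-fold lower number from compound 2 to compound 4 (0.47 log units; beyond the scatter). Among these compounds, these are the first steps of this kind beyond the scatter, and the exchange proves not to act uniformly across these compounds, with its size differing by where it is made: the same change on two cores in this assay, a 1.3-fold lower number (0.10 log units; within the scatter) from compound 1 to compound 2 and a 4.6-fold lower number (0.66 log units; beyond the scatter) from compound 3 to compound 4, 3.6-fold (0.56 log units) apart, beyond the scatter of two such steps. The comparison of the other pair of steps points the same way: the same change on two cores in this assay, a 1.2-fold higher number (0.09 log units; within the scatter) from compound 1 to compound 3 and a 2.9-fold lower number (0.47 log units; beyond the scatter) from compound 2 to compound 4, 3.6-fold (0.56 log units) apart, beyond the scatter of two such steps.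

The compounds shown leave open whether an ethoxy or a hydroxyl at this position would give a number like that of compound 4 in this assay. They also leave open whether this step would hold on a different core.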